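Trimming the pentyl chain of compound 1 to methyl

The source may report more compounds than this note shows. Statements on the series, on what has been measured and on what is new or still open speak of the compounds shown alone.

Compound 1, `CCCCCc1ccc(-c2oc3nc(=O)n([C@H]4C[C@H](OC(C)=O)[C@@H](COC(C)=O)O4)cc3c2C#CCCO)cc1`, is one of three closely related compounds tested in an ADME assay on HEL cells (Homo sapiens) for cytotoxicity, read by cell counting, with a stated time of 3 days (a lower number here means that less compound is tolerated, a higher number that more compound is tolerated), where compound 1 gives 100000 nM. Compound 2, `CCCCCc1ccc(-c2oc3nc(=O)n([C@H]4C[C@H](OC(C)=O)[C@@H](COC(C)=O)O4)cc3c2C#CCO)cc1`, gives 100000 nM in this assay, and compound 3, `CCCCCc1ccc(C#Cc2c(-c3ccc(CCCCC)cc3)oc3nc(=O)n([C@H]4C[C@H](OC(C)=O)[C@@H](COC(C)=O)O4)cc23)cc1`, gives 100000 nM, so compound 1 stands level with both at the digits shown. The measured steps confirm this: no change at the digits printed from compound 1 to compound 2 (within the scatter), no change at the digits printed from compound 1 to compound 3 (within the scatter) and no change at the digits printed from compound 2 to compound 3 (within the scatter). Compound 4, `CC(=O)OC[C@H]1O[C@@H](n2cc3c(C#CCCO)c(-c4ccc(C)cc4)oc3nc2=O)C[C@@H]1OC(C)=O`, differs from compound 1 by hydrogen in place of butyl on a saturated chain carbon bound to an aromatic carbon. For the measured compounds named here, none of the measured steps touches the 4-pentylphenyl group in this way, so no step bears directly on the change; the measured steps, each without change beyond the scatter, only show that changes at the triple-bonded carbon left this assay untouched. He therefore expects no step beyond the scatter, with no change at the digits printed from compound 1 to compound 4 (within the scatter), and estimates for compound 4 a minimum cytotoxic concentration of 100000 nM, within a range from 40000 nM to 200000 nM.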

Compound 4, minimum cytotoxic concentration: > 100000 nM
Compound 4: a limit, no number; the forecaster's own chance of this, stated with the estimate: 50%; the middle value sits exactly at the limit.
By their numbers in this assay, from the lowest: compounds 1, 2 and 3 (each within the scatter of the next).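

Going from 4-pentylphenyl to 4-methylphenyl gives a number no lower from compound 1 to compound 4 (the limit leaves the size open) in this assay, and this is the only step shown at the saturated chain carbon bound to an aromatic carbon, since all the earlier steps lay on the triple-bonded carbon. For the compounds shown here, the reading for compound 4 is a limit and not a number: the limit of > 100000 nM in this assay, at which 1 of the 4 values shown sits. So removing butyl at this place brought no measurable drop in the tolerated concentration, which the earlier compounds could not show, but the size of the step cannot be read.

The compounds shown leave open how far the true value of compound 4 lies from its limit. They also leave open whether a longer chain than pentyl, or an amine or a carboxylic acid at the end of the chain, would keep this reading.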